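Series notes: carboxy in place of carbamoyl on the core

A few compounds are considered here, and "the series" means these few. Any claim that something is new, unique, unknown or untested is made for them only; others in the source may bear on it.

Measured so far in a functional assay on Ehrlich cells (Mus musculus) for cytotoxicity, read by trypan blue exclusion, with a stated time of 2 h; a lower number here means a stronger inhibitor, a higher number a weaker inhibitor:
compound 1 `N#CC1=C(N)N(c2ccc(S(N)(=O)=O)cc2)C2=C(C(=O)CCC2)C1c1ccc(Cl)cc1Cl` gives 25 ug/mL
compound 2 `N#CC1=C(NC(=O)/C=C/c2ccccc2)N(c2ccc(S(N)(=O)=O)cc2)C2=C(C(=O)CCC2)C1c1ccc(Cl)cc1Cl` gives > 100 ug/mL
compound 3 `NC(=O)C1=C(N)N(c2ccc(S(N)(=O)=O)cc2)C2=C(C(=O)CCC2)C1c1ccc(Cl)cc1Cl` gives > 100 ug/mL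

The values of compound 2 and compound 3 in this assay are limits of the assay, not numbers. Compound 3 sits at the limit of > 100 ug/mL in this assay, at which 2 of the 3 values shown sit. Compound 4 `NC1=C(C(=O)O)C(c2ccc(Cl)cc2Cl)C2=C(CCCC2=O)N1c1ccc(S(N)(=O)=O)cc1` differs from compound 3 by hydroxy in place of amino on a carbonyl carbon. Among the compounds with values here, no measured step covers this exchange. Within the data shown here, the steps that bear on it are those leading away from compound 1: an at least 4.0-fold higher number from compound 1 to compound 3 (0.60 log units; beyond the scatter) and an at least 4.0-fold higher number from compound 1 to compound 2 (0.60 log units; beyond the scatter), both ending at the limit. Compound 3 already sits at the limit, so the step that the limit leaves unreadable from compound 3 to compound 4 is expected to be small and compound 4 is expected to remain there. Compound 4 is estimated at 150 ug/mL, within 50 ug/mL to 400 ug/mL, most likely reported only as a limit.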

Compound 4, half-maximal inhibitory concentration: > 100 ug/mL
Compound 4: a limit, no number; the forecaster's own chance of this, stated with the estimate: 75%; the middle value lies beyond the limit too.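

In this assay, carboxy in place of cyano on the double-bonded ring carbon gives an at least 4.0-fold higher number from compound 1 to compound 4 (0.60 log units; beyond the scatter), so carboxy, like carbamoyl, ends at the limit. Compound 4 gives > 100 ug/mL, which is a limit of the assay and not a number. The step from carbamoyl to carboxy cannot be read, and the series now gathers at one end: the limit of > 100 ug/mL in this assay, at which 3 of the 4 values shown sit.

On these data alone, how far compound 2, compound 3 and compound 4 lie past the limit stays open. Also open, as far as these compounds go, is whether a methyl ester on this carbonyl carbon, or an acetyl group on the amine nitrogen, gives a readable value.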